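The source may hold more compounds than are shown below. What is called first, only, known or untested is meant among the compounds shown, and "the series" means these compounds.

Compound 1 `O=C(Nc1ccccc1)Nc1cccc(-c2nc(-c3ccc(NC(=O)c4cccnc4)cc3Cl)no2)c1` gives in a functional assay on MDA-MB-231 cells (Homo sapiens) for antiproliferative activity, read by MTT assay, with a stated time of 72 h (on this read-out lower numbers stand for stronger inhibition and higher numbers for weaker inhibition), only a limit, > 10000 nM. Compound 2 `Cc1ccc(NC(=O)Nc2cccc(-c3nc(-c4ccc(NC(=O)c5cccnc5)cc4Cl)no3)c2)cc1` gives 3500 nM. Compound 3 `CS(=O)(=O)Nc1ccc(NC(=O)Nc2cccc(-c3nc(-c4ccc(NC(=O)c5cccnc5)cc4Cl)no3)c2)cc1` gives 600 nM.

Among these, compound 3 stands lowest of the two numbers, and a 5.8-fold lower number from compound 2 to compound 3 (0.77 log units; beyond the scatter) lies beyond the scatter, as does an at least 16-fold lower number from compound 1 to compound 3 (1.22 log units; beyond the scatter); an at least 2.8-fold lower number from compound 1 to compound 2 (0.45 log units; beyond the scatter) is smaller. Compound 4 `CC(=O)Nc1ccc(NC(=O)Nc2cccc(-c3nc(-c4ccc(NC(=O)c5cccnc5)cc4Cl)no3)c2)cc1Cl` differs from compound 3 by 4-acetamido-3-chlorophenyl in place of 4-(methanesulfonamido)phenyl on an amide-type nitrogen. For the measured compounds named here, no measured step exchanges these two groups directly; the measured steps show only that what sits on that aromatic carbon matters, and that the methanesulfonamido group gave the lowest number so far. The new group keeps an amide-type linkage, so a step of at most modest size, most likely toward a higher number, is expected. Compound 4 is therefore expected near 1200 nM, between 350 nM and 4000 nM, the expected step being a 2.0-fold higher number from compound 3 to compound 4 (0.30 log units; within the scatter).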

Compound 4, half-maximal inhibitory concentration: > 10000 nM
Compound 4 was reported as a limit; the forecaster's own chance of this, stated with the estimate: 5%; middle value at least 8.3-fold (0.92 log units) from the limit.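

In this assay, a substituted ring on the amide-type nitrogen does not by itself keep the activity: 4-acetamido-3-chlorophenyl in place of 4-(methanesulfonamido)phenyl gives an at least 16-fold higher number from compound 3 to compound 4 (1.22 log units; beyond the scatter). An amide-type linkage in the entering group therefore does not carry over what the methanesulfonamido group gave, and the same change against 4-methylphenyl gives an at least 2.8-fold higher number from compound 2 to compound 4 (0.45 log units; beyond the scatter). Compound 1 and compound 4 both stand at a limit, and the step between them cannot be read: the limit of > 10000 nM in this assay, at which 2 of the 4 values shown sit.

Whether the acetamido group or the chlorine accounts for the loss stays open. So does how an amine or a carboxylic acid would read in place of the methanesulfonamido group.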